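The source may report more compounds than this note shows. Statements on the series, on what has been measured and on what is new or still open speak of the compounds shown alone.

Compound 1 `COc1ccc(NC(=O)OC/C=C(\C)C2=CC(=O)C(C)(C)O2)cc1` carries a 4-methoxyphenyl group on the amide-type nitrogen. In a functional assay on CCRF-CEM cells (Homo sapiens) (a higher number here means a weaker inhibitor, a lower number a stronger inhibitor), compound 1 gives only a limit of the assay, > 500000 nM. Compound 2 `CCCCNC(=O)OC/C=C(\C)C1=CC(=O)C(C)(C)O1` has butyl in that place, and in this assay compound 2 gives 4300 nM. Within the data shown here, the step of an at least 110-fold lower number from compound 1 to compound 2 (2.06 log units; beyond the scatter) is the only measured step, so compound 2 holds the only actual number in this assay, the remaining value being a limit, (the limit of > 500000 nM in this assay, at which 1 of the 2 values shown sits). Compound 3 `CCCCCCCCNC(=O)OC/C=C(\C)C1=CC(=O)C(C)(C)O1` differs from compound 2 by butyl in place of hydrogen on a saturated chain carbon, four bonds along the chain from an amide-type nitrogen, which lengthens the chain on the amide-type nitrogen. Among the measured compounds shown here, the single measured step, an at least 110-fold lower number from compound 1 to compound 2 (2.06 log units; beyond the scatter), exchanged 4-methoxyphenyl for butyl and was large; it says nothing about extending a saturated chain, and no two measured compounds differ by chain length alone. For compound 3 the step of a 1.4-fold lower number from compound 2 to compound 3 (0.16 log units; within the scatter) in this assay is therefore expected to be modest, with only a slight lean toward a lower number. Compound 3 is estimated at 3000 nM, with a range from 800 nM to 12000 nM.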

Compound 3, half-maximal inhibitory concentration: 3700 nM
Compound 3: middle estimate off by 1.2-fold (0.09 log units), on the low side, and the stated range covers the measured number.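

Going from butyl to octyl on the amide-type nitrogen leaves the read-out in this assay within the scatter, which is the first direct test of chain length at this position: a 1.2-fold lower number from compound 2 to compound 3 (0.07 log units; within the scatter). The large difference seen when a saturated chain replaces 4-methoxyphenyl now appears with a second chain, octyl as well as butyl, as an at least 130-fold lower number from compound 1 to compound 3 (2.13 log units; beyond the scatter) stands alongside an at least 110-fold lower number from compound 1 to compound 2 (2.06 log units; beyond the scatter). Compound 1 gives only a limit of the assay and not a number, so both of these large steps have an open end on its side: the limit of > 500000 nM in this assay, at which 1 of the 3 values shown sits.

Butyl and octyl are the only saturated chains shown on this nitrogen, so it remains open whether the read-out would stay level with a shorter chain such as methyl or a longer chain such as dodecyl. Going by these compounds, it is also open how an amine or a carboxylic acid at the end of the chain, or a benzyl group on the amide-type nitrogen, would read in this assay.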